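Halogen swap on the saturated ring carbon of compound 1

A few compounds are considered here, and "the series" means these few. Any claim that something is new, unique, unknown or untested is made for them only; others in the source may bear on it.

Compound 1 `O=C1CSC(c2ccc(F)cc2)N1CCN1CCCCC1` gives 14% in an ADME assay on Vero cells (Chlorocebus sabaeus) for cytotoxicity, read by neutral red uptake, tested at 1575 ug/mL; a higher number here means a weaker effect of the compound at the concentration tested, a lower number a stronger effect. Compound 2 `COc1ccc(C2SCC(=O)N2CCN2CCCCC2)cc1` gives 11% in this assay, and the step of a number 3 percentage points lower from compound 1 to compound 2 (within the scatter) came with methoxy in place of fluoro on an aromatic carbon. On these two numbers compound 1 sits within the scatter of compound 2, so neither stands apart. Compound 3 `O=C1CSC(c2cccc(Cl)c2)N1CCN1CCCCC1` is unmeasured; its difference from compound 1 is 3-chlorophenyl in place of 4-fluorophenyl on a saturated ring carbon. Going by the values given here, the one step that bears on it, a number 3 percentage points lower from compound 1 to compound 2 (within the scatter), also replaced the group on that saturated ring carbon and stayed within the scatter, so no step beyond the scatter is expected: no change at the digits printed from compound 1 to compound 3 (within the scatter). Compound 3 is estimated at 14%, range 4% to 24%.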

Compound 3, a percentage reported as activity, at one concentration (the size of the read-out at that concentration, not a potency): 20%
Estimate against measurement, compound 3: 6 percentage points below; low and high end bracket the measured number.
By their numbers in this assay, from the lowest: compounds 2, 1 and 3 (each within the scatter of the next).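

In this assay, 3-chlorophenyl in place of 4-fluorophenyl on the saturated ring carbon gives a number 6 percentage points higher from compound 1 to compound 3 (within the scatter). A second replacement at this position, now changing both the halogen and its place on the aromatic ring, therefore also stays within the scatter, though the two changes cannot be read apart. No measurement on hand bears on a cause for this step. Still open, going by these compounds, is whether a carboxylic acid or an amine on the aromatic ring would leave the read-out within the scatter. A longer chain in place of the aromatic ring is equally untested by these compounds.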